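Halogen Swap on Two Related Anilino Quinone Cores

A few compounds are considered here, and "the series" means these few. Any claim that something is new, unique, unknown or untested is made for them only; others in the source may bear on it.

Compound 2 `O=C1C=C(Nc2cccc(Cl)c2)C(=O)c2c1nc1n2[C@H]2OC[C@@H](O)[C@H]2OC1` and compound 3 `O=C1C(Nc2cccc(Cl)c2)=CC(=O)c2c1nc1n2[C@H]2OC[C@@H](O)[C@H]2OC1` are built from the same atoms joined differently; the difference between the two cores is not broken down here. Compound 1 `O=C1C=C(Nc2cccc(F)c2)C(=O)c2c1nc1n2[C@H]2OC[C@@H](O)[C@H]2OC1` shares the core of compound 2. In a functional assay on ECa-109 cells for inhibition, with ECa-109 cell line (Homo sapiens) as the target, read by sulforhodamine B assay (a higher number here means a weaker inhibitor, a lower number a stronger inhibitor), compound 1 gives 7030 nM, compound 2 gives 4690 nM and compound 3 gives 3080 nM. The change from compound 2 to compound 1 is fluoro in place of chloro on an aromatic carbon, and it made a 1.5-fold higher number from compound 2 to compound 1 (0.18 log units; within the scatter). Compound 4 `O=C1C(Nc2cccc(F)c2)=CC(=O)c2c1nc1n2[C@H]2OC[C@@H](O)[C@H]2OC1` arises from compound 3 by the same change, (fluoro in place of chloro on an aromatic carbon), which occurs twice among these four compounds. Since the measured instance stayed within the scatter, the expected step in this assay is likewise small, and compound 4 is expected to show a 1.5-fold higher number from compound 3 to compound 4 (0.17 log units; within the scatter). That expectation rests on compound 2 giving 4690 nM while compound 1 gives 7030 nM after the same halogen swap. For compound 4 the expected value in this assay is 4600 nM, with a range from 2000 nM to 10000 nM.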

Compound 4, half-maximal inhibitory concentration: 2370 nM
For compound 4 the middle estimate is 1.9-fold (0.29 log units) above the measured one; measured number inside the range.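

In this assay, putting fluoro in place of chloro on the aromatic carbon of the core of compound 3 gives a 1.3-fold lower number from compound 3 to compound 4 (0.11 log units; within the scatter). Set beside the same swap on the core of compound 1, the two steps do not separate: the same change on two cores in this assay, a 1.5-fold higher number (0.18 log units; within the scatter) from compound 2 to compound 1 and a 1.3-fold lower number (0.11 log units; within the scatter) from compound 3 to compound 4, 1.9-fold (0.29 log units) apart, within the scatter of two such steps. For the compounds shown here, the swap therefore stays small on both cores, but with only one pair per core and both steps this small, this does not show that the two cores respond alike to a change with a larger effect.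

The compounds shown compare only (3-chlorophenyl)amino and (3-fluorophenyl)amino, so they leave open what a methoxy group, a nitrile or an amine at that place on the ring would give. They also leave open whether a step seen with such a group on one core would carry over to the other.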